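Terminal ring swap on the hydrazone arm of the core

The source may report more compounds than this note shows. Statements on the series, on what has been measured and on what is new or still open speak of the compounds shown alone.

Within the data shown here, compound 1 `COc1cc(OC)c2c(=O)c(OCC(=O)N/N=C/c3ccccc3F)c(-c3cc(OC)c(OC)c(OC)c3)oc2c1` gives 3400 nM in a functional assay on MDA-MB-231 cells (Homo sapiens) for cytotoxicity, read by MTT assay, with a stated time of 38 h (a lower number here means a stronger inhibitor, a higher number a weaker inhibitor), the lowest of the three numbers so far. Compound 3 `COc1cc(OC)c2c(=O)c(OCCCCN3CCN(C)CC3)c(-c3cc(OC)c(OC)c(OC)c3)oc2c1` gives 3870 nM, within the scatter of compound 1, while compound 2 `COc1cc(OC)c2c(=O)c(OCCCCN3CCCC3)c(-c3cc(OC)c(OC)c(OC)c3)oc2c1` gives 10400 nM; the step of a 3.1-fold higher number from compound 1 to compound 2 (0.49 log units; beyond the scatter) lies beyond the scatter, as does a 2.7-fold lower number from compound 2 to compound 3 (0.43 log units; beyond the scatter). Compound 4 `COc1cc(OC)c2c(=O)c(OCC(=O)N/N=C/c3ccccn3)c(-c3cc(OC)c(OC)c(OC)c3)oc2c1` keeps the arm of compound 1 and alters only the ring on the carbon with a double bond to nitrogen: pyridin-2-yl in place of 2-fluorophenyl on a carbon with a double bond to nitrogen. Among the measured compounds shown here, no measured step changes this ring alone; both a 3.1-fold higher number from compound 1 to compound 2 (0.49 log units; beyond the scatter) and a 1.1-fold higher number from compound 1 to compound 3 (0.06 log units; within the scatter) replace the whole arm. Exchanging one six-membered aromatic ring for another within a retained arm is expected to give no step beyond the scatter in this assay. Compound 4 is therefore estimated at 3200 nM (range 1500 nM to 7000 nM), a step of a 1.1-fold lower number from compound 1 to compound 4 (0.03 log units; within the scatter).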

Compound 4, half-maximal inhibitory concentration: 9890 nM
Compound 4: the middle estimate sits 3.1-fold (0.49 log units) below what was measured; the measured number lies above the stated range.
By their numbers in this assay, from the lowest: compounds 1 and 3 (each within the scatter of the next); then compounds 4 and 2 (each within the scatter of the next).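

With the arm retained, pyridin-2-yl in place of 2-fluorophenyl gives a 2.9-fold higher number from compound 1 to compound 4 (0.46 log units; beyond the scatter) in this assay and shows that this ring alone can move the number beyond the scatter. The arm itself does not settle the value: a 2.6-fold higher number from compound 3 to compound 4 (0.41 log units; beyond the scatter) is beyond the scatter, while a 1.1-fold lower number from compound 2 to compound 4 (0.02 log units; within the scatter) is within it, although compound 3 and compound 2 both lack this arm. Nothing available explains the effect of this ring change.

The compounds shown leave open whether the change follows the loss of fluorine or the entry of the ring nitrogen. Unsubstituted phenyl and pyridin-3-yl on the same carbon would separate these two changes.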